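A few compounds are considered here, and "the series" means these few. Any claim that something is new, unique, unknown or untested is made for them only; others in the source may bear on it.

Measured compounds in a functional assay on Caco-2 cells (Homo sapiens) for inhibition, read by sulforhodamine B assay, with a stated time of 48 h; on this read-out higher numbers stand for weaker inhibition and lower numbers for stronger inhibition:

Compound 1, `O=c1c([C@@H]2C[C@H](c3ccccc3)ON2c2ccccc2)coc2cc(Cl)c(Cl)cc12`, gives 23500 nM.
Compound 2, `Cc1ccc2occ([C@@H]3C[C@H](c4ccccc4)ON3c3ccccc3)c(=O)c2c1`, gives 31700 nM.
Compound 3, `Cc1ccc2occ([C@@H]3[C@H]4C(=O)N(c5ccccc5)C(=O)[C@H]4ON3c3ccccc3)c(=O)c2c1`, reaches only a limit of the assay, > 60000 nM.

Compound 1 and compound 2 give numbers that lie within the usual scatter of each other, so nothing separates them. Compound 3 stands apart: for compound 3 no number was obtained, only a limit, since its inhibition did not reach half-maximal within the range tested, as shown by the limit of > 60000 nM in this assay, at which 1 of the 3 values shown sits. Compound 3 is thus the only one of the three for which the read-out has no finite value.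

Compound 4, `O=C1[C@H]2[C@H](ON(c3ccccc3)[C@@H]2c2coc3ccc(F)cc3c2=O)C(=O)N1c1ccccc1`, shares the core of compound 3 and differs from it in a single place: fluoro in place of methyl on an aromatic carbon. Going by the values given here, no pair of measured compounds differing in one place is available here, so there is no measured step to lean on for the size of this exchange. With compound 3 already at the limit, the expectation is a step of no size beyond the scatter, and a value that again sits at or beyond the limit. Compound 4 is therefore estimated at 80000 nM, with a range from 30000 nM to 200000 nM. The expected step is a step that the limit leaves unreadable from compound 3 to compound 4.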

Compound 4, half-maximal inhibitory concentration: > 60000 nM
Compound 4 ended at the assay's limit; the forecaster's own chance of this, stated with the estimate: 70%; the middle value lies beyond the limit too.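

Compound 3 and compound 4 both end at a limit of this assay and not at a number, so the step between them cannot be read: the limit of > 60000 nM in this assay, at which 2 of the 4 values shown sit.

The compounds shown leave open how large the exchange of methyl for fluoro is, and no pair of them differing in one place carries two finite numbers.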